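Aryl amine change on the shared core: toward compound 4

This account rests on a few compounds, and the source may have more. Where it says the series, first, only, none or still open, it means among the compounds named here.

compound 1 `COc1cc2ncnc(Nc3ccc(F)cc3)c2cc1OCCCCC(=O)Nc1ccc(S(N)(=O)=O)cc1` — in a functional assay on NCI-H1975 cells (Homo sapiens) for antiproliferative activity, read by MTT assay, with a stated time of 72 h (a higher number here means a weaker inhibitor, a lower number a stronger inhibitor), compound 1 gives > 40000 nM, a limit only
compound 2 `COc1cc2ncnc(Nc3ccc(F)c(Br)c3)c2cc1OCCCCC(=O)Nc1ccc(S(N)(=O)=O)cc1` — compound 2 gives 31600 nM
compound 3 `COc1cc2ncnc(Nc3cc(F)c(F)c(F)c3)c2cc1OCCCCC(=O)Nc1ccc(S(N)(=O)=O)cc1` — compound 3 gives 20000 nM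

Compound 1 stands only at the limit of the assay, (the limit of > 40000 nM in this assay, at which 1 of the 3 values shown sits), so no number is known for it. Compound 4 `COc1ccccc1Nc1ncnc2cc(OC)c(OCCCCC(=O)Nc3ccc(S(N)(=O)=O)cc3)cc12` differs from compound 1 by 2-methoxyphenyl in place of 4-fluorophenyl on a nitrogen on an aromatic ring. Within the data shown here, the steps that bear on this change, both at the same place on the shared core, are an at least 1.2-fold lower number from compound 1 to compound 2 (0.10 log units; that floor lies within the scatter) and an at least 2.0-fold lower number from compound 1 to compound 3 (0.30 log units; that floor lies within the scatter); each rests on the limit of compound 1 and neither rises beyond the scatter, and a 1.6-fold lower number from compound 2 to compound 3 (0.20 log units; within the scatter) is likewise within it. No step beyond the scatter is therefore expected for compound 4, and a limit is as likely as a number. Compound 4 is estimated at 45000 nM, between 18000 nM and 120000 nM. The expected step is a step that the limit leaves unreadable from compound 1 to compound 4.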

Compound 4, half-maximal inhibitory concentration: 8030 nM
For compound 4 the middle estimate is 5.6-fold (0.75 log units) above the measured one, and the stated range ends above it.
By their numbers in this assay, from the lowest: compound 4; then compounds 3 and 2 (each within the scatter of the next). At a limit, above all of these: compound 1.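

Among these compounds, at this place, on a nitrogen on an aromatic ring, 2-methoxyphenyl gives the first steps in this assay that are measured on both sides and lie beyond the scatter: a 2.5-fold lower number from compound 3 to compound 4 (0.40 log units; beyond the scatter) and a 3.9-fold lower number from compound 2 to compound 4 (0.59 log units; beyond the scatter). Against the 4-fluorophenyl group the reading is an at least 4.9-fold lower number from compound 1 to compound 4 (0.69 log units; beyond the scatter). Compound 1 stands only at a limit: the limit of > 40000 nM in this assay, at which 1 of the 4 values shown sits.

Going by these compounds, whether the methoxy group alone carries these steps stays open. Also open, on these data alone, is how an ethoxy group, a hydroxyl or an amine would read in its place on the same ring.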